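Swapping the sulfur-linked arm: from compound 2 to compound 3

A few compounds are considered here, and "the series" means these few. Any claim that something is new, unique, unknown or untested is made for them only; others in the source may bear on it.

Of the compounds shown here, two built on one shared core have been measured in an ADME assay on GES1 cells (Homo sapiens) for inhibition, read by MTT assay, with a stated time of 72 h; a lower number here means a stronger inhibitor, a higher number a weaker inhibitor. Compound 1 `Cc1cc(Nc2cc(-c3cccs3)[nH]n2)n2nc(SCc3ccc(Br)cc3)nc2n1` gives 38700 nM. Compound 2 `Cc1cc(Nc2cc(-c3ccccc3)[nH]n2)n2nc(SCC(=O)c3ccccc3)nc2n1` gives 33300 nM. Compound 2 therefore stands at the lower of the two numbers, but its gap to compound 1 is within the scatter of repeated measurements, so the two are best read as equally weak inhibitors.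

The next compound, compound 3 `Cc1cc(Nc2cc(-c3ccccc3)[nH]n2)n2nc(SCc3ccc(C(F)(F)F)cc3)nc2n1`, has not yet been tested in this assay. It keeps the core and the phenyl group of compound 2 and changes only the arm attached to the sulfur: 4-(trifluoromethyl)phenyl in place of benzoyl on a saturated chain carbon bound to a sulfur. In the new arm the chain ends in a benzene ring bearing a trifluoromethyl group, which resembles the bromine-bearing benzyl arm of compound 1 more than the benzoylmethyl arm of compound 2.

Among the measured compounds shown here, no step between measured compounds has been recorded here, so there is nothing to calibrate against. The expectation is that this exchange moves the number little, and the step of a 1.1-fold higher number from compound 2 to compound 3 (0.02 log units; within the scatter) is estimated to lie within the scatter. Compound 3 is therefore expected to give about 35000 nM, with a likely range from 15000 nM to 80000 nM.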

Compound 3, half-maximal inhibitory concentration: 42700 nM
Compound 3: the middle estimate sits 1.2-fold (0.09 log units) below what was measured; measured number inside the range.
By their numbers in this assay, from the lowest: compounds 2, 1 and 3 (each within the scatter of the next).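

In this assay, among the compounds shown here, the step of a 1.3-fold higher number from compound 2 to compound 3 (0.11 log units; within the scatter) is the first comparison here of two compounds that differ in one place, and it shows this position tolerating the exchange of benzoyl for 4-(trifluoromethyl)phenyl on a saturated chain carbon bound to a sulfur without a readable change in the number. The group that leaves holds the carbonyl and 1 hydrogen-bond acceptor, while the group that enters has 0 hydrogen-bond acceptors and carries three fluorine atoms instead, so in this pair neither feature can be seen to matter for the read-out. Why the number holds steady cannot be said, as no measurement bearing on a cause is available for this pair.

Every arm shown ends in a benzene ring, so it remains open whether an arm ending in an amine or a carboxylic acid would give a number beyond the scatter. A longer chain between the sulfur and the ring is equally untested by these compounds, and a single step cannot show whether the same exchange would behave alike on another core.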